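Swapping the sulfur-linked heteroaryl in a thiazolylidene hydrazide series

The source may report more compounds than this note shows. Statements on the series, on what has been measured and on what is new or still open speak of the compounds shown alone.

Measured so far in an ADME assay on NIH3T3 cells (Mus musculus) for cytotoxicity, read by MTT assay, with a stated time of 24 h; on this read-out lower numbers stand for stronger inhibition and higher numbers for weaker inhibition:
- compound 1 `Cc1nnc(SCC(=O)N/N=c2/scc(-c3ccc(F)cc3)n2-c2ccccc2)s1`: 383 ug/mL
- compound 2 `Cc1nnc(SCC(=O)N/N=c2/scc(-c3ccc([N+](=O)[O-])cc3)n2-c2ccccc2)s1`: 177 ug/mL
- compound 3 `Cc1nnc(SCC(=O)N/N=c2/scc(-c3ccc(Cl)cc3)n2-c2ccccc2)s1`: 253 ug/mL

Compound 2 gives the lowest of the three numbers in this assay. Its gap to compound 3 lies within the scatter, so the two cannot be ordered; the step of a 2.2-fold lower number from compound 1 to compound 2 (0.34 log units; beyond the scatter) is the only one beyond the scatter, and the step of a 1.5-fold lower number from compound 1 to compound 3 (0.18 log units; within the scatter) is not.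

Compound 4 `O=C(CSc1nnnn1-c1ccccc1)N/N=c1/scc(-c2ccc([N+](=O)[O-])cc2)n1-c1ccccc1` is not yet measured. It differs from compound 2 by 1-phenyl-1H-tetrazol-5-yl in place of 5-methyl-1,3,4-thiadiazol-2-yl on a sulfur. All three measured steps change a group on the other aromatic ring, the one carrying fluoro, chloro or nitro, and none touches the heteroaryl on the sulfur. The measured steps therefore say nothing direct about this change, and the measured numbers all fall within a narrow band.

Going by the values given here, with no bearing step, no shift beyond the scatter is expected, and the step of a 1.1-fold lower number from compound 2 to compound 4 (0.04 log units; within the scatter) is the estimate. Compound 4 is expected to give 160 ug/mL in this assay, with a range from 65 ug/mL to 400 ug/mL.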

Compound 4, half-maximal inhibitory concentration: 14.3 ug/mL
Compound 4: the middle estimate sits 11-fold (1.05 log units) above what was measured; measured number below the stated range.
By their numbers in this assay, from the lowest: compound 4; then compounds 2, 3 and 1 (each within the scatter of the next, the first and the last beyond it).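

In this assay the group on the sulfur proves a far stronger lever than the substituent on the other aromatic ring: a 12-fold lower number from compound 2 to compound 4 (1.09 log units; beyond the scatter) is a large step, while exchanging fluoro, chloro and nitro produced a modest step at most. The entering 1-phenyl-1H-tetrazol-5-yl has 11 heavy atoms against 6 for the departing 5-methyl-1,3,4-thiadiazol-2-yl and brings an additional six-membered aromatic ring of carbon only, so the change is more than a swap of one five-membered ring for another. Nothing measured here accounts for the step.

On these data alone, whether the tetrazole ring or its phenyl carries the effect stays open, and a tetrazole bearing methyl instead of phenyl would separate the two. Also open, as far as these compounds go, is whether the swap does as much with fluoro or chloro on the other aromatic ring.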